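Two urea compounds, and a third with a fluorine swap

The compounds below may be only part of what the source reports. "The series", "measured", "known", "first", "only" and "open" are said of these compounds alone.

Two ureas sharing one core have been measured. Compound 2 `Cc1ccc(NC(=O)Nc2cc(C)nc3ccccc23)cc1` is tested in an ADME assay for permeability, using PAMPA, at pH 7.4 (a lower number here means that the compound crosses the layer more slowly, a higher number that the compound crosses the layer faster), and gives 669 10^-6 cm/s. Compound 1 `Cc1cc(NC(=O)Nc2cc(F)ccc2F)c2ccccc2n1` in this assay gives 541 10^-6 cm/s; the two numbers lie within the usual scatter of each other, so neither stands apart. Compound 3 `Cc1cc(NC(=O)Nc2ccccc2F)c2ccccc2n1` differs from compound 2 by 2-fluorophenyl in place of 4-methylphenyl on an amide-type nitrogen. With no comparable change yet measured, the step is expected to be small, within the scatter, as seen in a 1.2-fold lower number from compound 2 to compound 3 (0.06 log units; within the scatter). The permeability of compound 3 is therefore estimated at 580 10^-6 cm/s, ranging from 350 10^-6 cm/s to 900 10^-6 cm/s.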

Compound 3, apparent permeability: 817 10^-6 cm/s
For compound 3 the middle estimate is 1.4-fold (0.15 log units) below the measured one; measured number inside the range.
By their numbers in this assay, from the lowest: compounds 1, 2 and 3 (each within the scatter of the next).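

Putting 2-fluorophenyl in place of 4-methylphenyl on the amide-type nitrogen gives a 1.2-fold higher number from compound 2 to compound 3 (0.09 log units; within the scatter) in this assay, so at this position one substituted phenyl can stand in for another with no readable effect on the number. Hydrogen in place of fluoro on an aromatic carbon gives a 1.5-fold higher number from compound 1 to compound 3 (0.18 log units; within the scatter), so this change shows no readable effect either. Nothing available explains these numbers. Still open, from the compounds shown here alone, is whether a different kind of group on this nitrogen, such as a carboxylic acid or a longer chain in place of the phenyl ring, would give a step beyond the scatter.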